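The source may report more compounds than this note shows. Statements on the series, on what has been measured and on what is new or still open speak of the compounds shown alone.

Measured so far:
compound 1, `COc1cccc(CCC(=O)N2CCN(c3ccc(C(F)(F)F)cc3[C@@H](N)CC(C)C)CC2)c1`: 4000 nM
compound 2, `CCC(C)CN[C@H](c1cc(C(F)(F)F)ccc1N1CCN(C(=O)CCc2ccc(Cl)cc2Cl)CC1)C(C)CC`: 2800 nM

In an assay on HEK293 cells for displacement of a labelled ligand from Melanocortin receptor 4 (Homo sapiens) (on this read-out higher numbers stand for weaker inhibition and lower numbers for stronger inhibition), compound 2 gives the lowest of the two numbers, and compound 1 sits within the scatter of it, so neither can be called stronger than the other. Compound 3, `CC(C)C[C@H](NC(=O)CCN)c1cc(C(F)(F)F)ccc1N1CCN(C(=O)CCc2ccc(Cl)cc2Cl)CC1`, is not yet measured. It differs from compound 2 in one place: 1-(((2-aminoethyl)carbonyl)amino)-3-methylbutyl in place of 2-methyl-1-((2-methylbutyl)amino)butyl on an aromatic carbon. Among the compounds with values here, no measured pair shows how such a change plays out here, so the expected step of a 1.1-fold higher number from compound 2 to compound 3 (0.03 log units; within the scatter) is no larger than the scatter, with no firm direction. Compound 3 is estimated at 3000 nM, with a range from 800 nM to 12000 nM.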

Compound 3, inhibition constant: 25 nM
Compound 3: the middle estimate sits 120-fold (2.08 log units) above what was measured; the measured number lies below the stated range.
By their numbers in this assay, from the lowest: compound 3; then compounds 2 and 1 (each within the scatter of the next).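

The aromatic carbon meta to a trifluoromethyl group proves highly sensitive in this assay, with a 110-fold lower number from compound 2 to compound 3 (2.05 log units; beyond the scatter) when 1-(((2-aminoethyl)carbonyl)amino)-3-methylbutyl replaces 2-methyl-1-((2-methylbutyl)amino)butyl. Both groups have 11 heavy atoms, so that count alone does not separate them; they differ in composition, and the entering group adds a carbonyl and a second nitrogen.

This single swap changes several features at once, leaving open whether the carbonyl, the terminal amine or the side chain accounts for the gain, and whether an acetyl amide without that amine or a longer aminoalkyl chain would do as well. No evidence shown here explains the gain.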